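The compounds below may be only part of what the source reports. "The series", "measured", "known", "first", "only" and "open" are said of these compounds alone.

Measured compounds:
compound 1 `Cc1ccc(NC(=S)NC(=O)c2ccc(OCc3ccc(C(F)(F)F)cc3)cc2)cc1-c1nc2ccccc2[nH]1` — 6500 nM
compound 2 `Cc1ccc(COc2ccc(C(=O)NC(=S)Nc3ccc(C)c(-c4nc5ccccc5[nH]4)c3)cc2)cc1` — 4980 nM
compound 3 `Cc1ccc(NC(=S)NC(=O)c2ccc(OCc3cccc(F)c3)cc2)cc1-c1nc2ccccc2[nH]1` — > 100000 nM

In a functional assay on MGC-803 cells (Homo sapiens) for inhibition, read by MTT assay, with a stated time of 48 h (a higher number here means a weaker inhibitor, a lower number a stronger inhibitor), compound 1 gives 6500 nM, the highest of the plain numbers shown. Compound 2 sits nearest, with 4980 nM, and the step is small: a 1.3-fold lower number from compound 1 to compound 2 (0.12 log units; within the scatter). The value of compound 3 is a limit of the assay, not a number; it sits at the limit of > 100000 nM in this assay, at which 1 of the 3 values shown sits. The steps to it are large: an at least 15-fold higher number from compound 1 to compound 3 (1.18 log units; beyond the scatter) and an at least 20-fold higher number from compound 2 to compound 3 (1.30 log units; beyond the scatter).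

Compound 4 `Cc1ccc(NC(=S)NC(=O)c2ccc(OCc3ccc(Cl)c(Cl)c3)cc2)cc1-c1nc2ccccc2[nH]1` has not yet been measured. It differs from compound 1 in one place: 3,4-dichlorophenyl in place of 4-(trifluoromethyl)phenyl on a saturated chain carbon bound to an oxygen on an aromatic ring. Within the data shown here, two measured steps bear on this position. Exchanging the trifluoromethyl for a methyl changed little, while exchanging the whole 4-(trifluoromethyl)phenyl for 3-fluorophenyl lost activity beyond the scatter. The entering 3,4-dichlorophenyl keeps a group at the 4-position but adds one at the 3-position, so the outcome lies between those two cases. A moderate weakening is therefore expected for compound 4, and the estimated step is a 1.8-fold higher number from compound 1 to compound 4 (0.27 log units; within the scatter). The expected value for compound 4 in this assay is 12000 nM, with a range from 3500 nM to 60000 nM.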

Compound 4, half-maximal inhibitory concentration: 6390 nM
Compound 4: the middle estimate sits 1.9-fold (0.27 log units) above what was measured; the range from low to high includes it.
By their numbers in this assay, from the lowest: compounds 2, 4 and 1 (each within the scatter of the next). At a limit, above all of these: compound 3.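

In this assay, among these compounds, the benzyl group on the ether oxygen tolerates a larger change than the earlier compounds showed, since 3,4-dichlorophenyl reads like 4-(trifluoromethyl)phenyl, with a 1.0-fold lower number from compound 1 to compound 4 (0.01 log units; within the scatter), and like 4-methylphenyl, with a 1.3-fold higher number from compound 2 to compound 4 (0.11 log units; within the scatter). Compound 3 carries a limit of the assay rather than a number: the limit of > 100000 nM in this assay, at which 1 of the 4 values shown sits. The 3,4-dichlorophenyl group still gives an at least 15-fold lower number from compound 3 to compound 4 (1.19 log units; beyond the scatter), so a substituent named at the 3-position does not by itself go with the loss of activity, and among these four compounds only the 3-fluorophenyl of compound 3 has no group named at the 4-position.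

Going by these compounds, whether that loss follows from the empty 4-position or from the fluorine remains open, and 4-fluorophenyl and 3-chlorophenyl would be the groups that could separate the two readings. On these data alone, the groups compared here hold only carbon, hydrogen and halogen atoms, so how an amine or a carboxylic acid at the 4-position of this ring would read also remains open.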